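The source may report more compounds than this note shows. Statements on the series, on what has been measured and on what is new or still open speak of the compounds shown alone.

Series notes. Compound 2 `O=C(NS(=O)(=O)c1ccccc1)c1ccc(Nc2nc(NC3(c4ccc(Cl)cc4)CC3)nc(OCC(F)(F)F)n2)cc1` carries a phenyl on the sulfonyl sulfur; in an ADME assay on microsomes from liver (Homo sapiens) for metabolic stability, with a stated time of 10 min (a higher number here means that more of the compound is left, a lower number that less of the compound is left), compound 2 gives 100%. Compound 1 `CC(C)OC(=O)NCCS(=O)(=O)NC(=O)c1ccc(Nc2nc(NC3(c4ccc(Cl)cc4)CC3)nc(OCC(F)(F)F)n2)cc1`, with the 2-((isopropoxycarbonyl)amino)ethyl in that place, gives 100% in this assay, and compound 3 `Cc1ccccc1S(=O)(=O)NC(=O)c1ccc(Nc2nc(NC3(c4ccc(Cl)cc4)CC3)nc(OCC(F)(F)F)n2)cc1`, with the 2-methylphenyl, gives 100%. Compound 2 thus stands level with both neighbours: the steps of no change at the digits printed from compound 1 to compound 2 (within the scatter), no change at the digits printed from compound 1 to compound 3 (within the scatter) and no change at the digits printed from compound 2 to compound 3 (within the scatter) all lie within the scatter.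

Compound 4 `CC(C)C(=O)NCCS(=O)(=O)NC(=O)c1ccc(Nc2nc(NC3(c4ccc(Cl)cc4)CC3)nc(OCC(F)(F)F)n2)cc1` has not yet been measured in this assay. Its difference from compound 2 is 2-((isopropylcarbonyl)amino)ethyl in place of phenyl on a sulfonyl sulfur. Going by the values given here, the step that bears on it most is the one from compound 1 to compound 2, since the group entering in compound 4 resembles the one that left there, and no change at the digits printed from compound 1 to compound 2 (within the scatter) was flat; the two aromatic substituents gave the same outcome. Among the compounds with values here, no measured step on this sulfur moved the read-out, so no step beyond the scatter is expected, a number 2 percentage points lower from compound 2 to compound 4 (within the scatter) being the estimated change. Compound 4 is therefore expected at 98% in this assay, with a range of 85% to 100%.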

Compound 4, percent of the compound remaining: 86%
Beside the measured number, compound 4's estimate is 12 percentage points above it; the range from low to high includes it.
By their numbers in this assay, from the lowest: compound 4; then compounds 1, 2 and 3 (each within the scatter of the next).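

In this assay the sulfonyl sulfur now shows a measurable response to its substituent: 2-((isopropylcarbonyl)amino)ethyl gives a number 14 percentage points lower from compound 2 to compound 4 (beyond the scatter) and a number 14 percentage points lower from compound 3 to compound 4 (beyond the scatter) against the two aromatic groups. Having a chain on the sulfur is not enough to produce this, as compound 1 stays level with compounds 2 and 3, while isopropyl in place of isopropoxy on a carbonyl carbon gives a number 14 percentage points lower from compound 1 to compound 4 (beyond the scatter) and so locates the difference at the far end of the chain. No measurement at hand accounts for this difference.

Still open, going by these compounds, is whether a methoxy on that carbonyl carbon, or a free amine at the end of the ethyl chain, would stay level with compound 1 or fall with compound 4. Also open, on these data alone, is how a longer chain on the sulfur would behave.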